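Swapping the Amine on a Thioamide Oxytocin Ligand

The compounds below may be only part of what the source reports. "The series", "measured", "known", "first", "only" and "open" are said of these compounds alone.

Of the compounds shown here, three sharing one core have been tested in an assay on isolated protein with Oxytocin receptor (Homo sapiens) as the target; a lower number here means that less compound is needed, a higher number that more compound is needed for the effect. Compound 1 `CO[C@@H]1C[C@@H](C(=O)NCCN(C)C)N(C(=O)NCc2ccc(C(=O)N3CCCCc4sccc43)cc2Cl)C1` gives > 10000 nM, which is a limit of the assay rather than a number. Compound 2 `CN1CCCN(C(=S)[C@@H]2CCCN2C(=O)NCc2ccc(C(=O)N3CCCCc4sccc43)cc2Cl)CC1` gives 810 nM. Compound 3 `CO[C@@H]1C[C@@H](C(=S)N2CCC(N3CCCC3)CC2)N(C(=O)NCc2ccc(C(=O)N3CCCCc4sccc43)cc2Cl)C1` gives 480 nM, the lowest of the two numbers, though its gap to compound 2 lies within the usual scatter, so the two cannot be told apart on these data.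

Compound 4 `CO[C@@H]1C[C@@H](C(=S)N2CCCN(C)CC2)N(C(=O)NCc2ccc(C(=O)N3CCCCc4sccc43)cc2Cl)C1` has not yet been measured. It differs from compound 3 in one place: 4-methyl-1,4-diazepan-1-yl in place of 4-(pyrrolidin-1-yl)piperidin-1-yl on a thiocarbonyl carbon. The same 4-methyl-1,4-diazepan-1-yl group already sits on the thiocarbonyl carbon of compound 2, whose core lacks the methoxy group, and compound 2 gives 810 nM.

Within the data shown here, with no measured step for this exact change, the step from compound 3 to compound 4 in this assay is expected to be small, a 1.3-fold higher number from compound 3 to compound 4 (0.10 log units; within the scatter), not clearly beyond the scatter in either direction. Compound 4 is therefore estimated at 600 nM, with a likely range from 200 nM to 2000 nM.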

Compound 4, half-maximal effective concentration: 430 nM
The estimate for compound 4 lay 1.4-fold (0.14 log units) above the measured number; the measured number falls inside the stated range.
By their numbers in this assay, from the lowest: compounds 4, 3 and 2 (each within the scatter of the next). At a limit, above all of these: compound 1.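

In this assay, placing 4-methyl-1,4-diazepan-1-yl instead of 4-(pyrrolidin-1-yl)piperidin-1-yl on the thiocarbonyl carbon gives a 1.1-fold lower number from compound 3 to compound 4 (0.05 log units; within the scatter), so these two differently built ring amines cannot be told apart at this position. Methoxy in place of hydrogen on the saturated ring carbon, with the 4-methyl-1,4-diazepan-1-yl group held fixed, gives a 1.9-fold lower number from compound 2 to compound 4 (0.28 log units; within the scatter), which also cannot be told from scatter. The only large step is an at least 23-fold lower number from compound 1 to compound 4 (1.36 log units; beyond the scatter), where the ringless group gives way to the sulfur-bearing ring group, and its size is only a bound set by a limit of the assay: the limit of > 10000 nM in this assay, at which 1 of the 4 values shown sits.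

That step changes the sulfur and the ring together, and the compounds shown cannot separate the two. A carbonyl carrying 4-methyl-1,4-diazepan-1-yl, or a thiocarbonyl carrying morpholine, would help to separate them.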